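This account rests on a few compounds, and the source may have more. Where it says the series, first, only, none or still open, it means among the compounds named here.

Compound 1 `CCC[C@@H](NC(=O)c1nccs1)c1cnc(Nc2ccc(C)nc2)c(Cl)c1` is tested in a functional assay on HEK293 cells for negative allosteric modulation of metabotropic glutamate receptor 5 (Homo sapiens), read by HTRF and inositol phosphate accumulation (on this read-out lower numbers stand for stronger inhibition and higher numbers for weaker inhibition), where compound 1 gives 8.2 nM, the lowest of the two numbers at hand. Among the compounds with values here, its companion compound 2 `Cc1ccc(Nc2ncc([C@H](NC(=O)c3nccs3)C3CCCC3)cc2Cl)cn1` gives 16.6 nM; the single measured step, a 2.0-fold higher number from compound 1 to compound 2 (0.31 log units; beyond the scatter), swaps a propyl chain for a cyclopentyl ring on the saturated carbon that carries the amide nitrogen. Compound 3 `CCC[C@@H](NC(=O)c1nccs1)c1cnc(Nc2cccnc2)c(Cl)c1` differs from compound 1 in another part of the molecule: hydrogen in place of methyl on an aromatic carbon, so a 6-methylpyridin-3-yl group becomes a plain pyridin-3-yl group. Within the data shown here, no measured step touches this position, and the one step known concerns a different site, so it gives no guide to direction or size. Compound 3 is therefore expected to move only a little, a 1.5-fold higher number from compound 1 to compound 3 (0.17 log units; within the scatter), within the usual scatter. The estimate for compound 3 in this assay is 12 nM, with a range from 4 nM to 35 nM.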

Compound 3, half-maximal inhibitory concentration: 71.4 nM
Estimate against measurement, compound 3: 6.0-fold (0.77 log units) below; measured number outside the range, above it.
By their numbers in this assay, from the lowest: compound 1; then compound 2; then compound 3.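

Taking the methyl off the 6-methylpyridin-3-yl group, so that hydrogen sits on the aromatic carbon next to the ring nitrogen, gives an 8.7-fold higher number from compound 1 to compound 3 (0.94 log units; beyond the scatter) in this assay. Within the data shown here, this is the first look at this position, and it shows that the loss of a single carbon atom here moves the number beyond the scatter, so the methyl cannot be treated as a detail that makes no difference. Nothing at hand explains this result.

Still open, on these data alone, is whether a larger group at this carbon, such as ethyl or methoxy, would bring the number lower than in compound 1 or raise it. Also open, as far as these compounds go, is whether the methyl counts for as much when the cyclopentyl ring of compound 2 replaces the propyl chain.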